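Methylsulfanyl in Place of Anilino on the Shared Core

The source may report more compounds than this note shows. Statements on the series, on what has been measured and on what is new or still open speak of the compounds shown alone.

Compound 3 `CNc1nc(Nc2ccccc2)nc(NC2(C#N)CCCCC2)n1` stands at a limit rather than a number: in an in vitro assay on Sf21 cells for inhibition of high affinity 3',5'-cyclic-AMP phosphodiesterase 7A (Homo sapiens) (a lower number here means a stronger inhibitor, a higher number a weaker inhibitor), compound 3 gives > 5000 nM, which is a limit of the assay. The two compounds measured beside it sit at the same limit. In this assay compound 1 `CNc1nc(NC2(C#N)CCCCC2)nc(-n2cccn2)n1` gives > 5000 nM, a limit. In this assay compound 2 `CNc1nc(NC2(C#N)CCCCC2)nc(N2CCCC2)n1` gives > 5000 nM, also a limit. All three values share (the limit of > 5000 nM in this assay, at which 3 of the 3 values shown sit), so the steps among them cannot be read: a step that the two limits leave unreadable from compound 1 to compound 3, a step that the two limits leave unreadable from compound 2 to compound 3 and a step that the two limits leave unreadable from compound 1 to compound 2. Compound 4 `CNc1nc(NC2(C#N)CCCCC2)nc(SC)n1` carries the change (methylsulfanyl in place of anilino on an aromatic carbon). The measured steps bearing on the exchanged group at that carbon, from compound 1 and from compound 2 to compound 3, are all unreadable, so no direction can be drawn from them. Compound 4 is therefore expected to remain near the same limit in this assay, with the step that the limit leaves unreadable from compound 3 to compound 4 taken as no readable change. The estimate for compound 4 is 8000 nM, within a range from 2000 nM to 30000 nM.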

Compound 4, half-maximal inhibitory concentration: 46 nM
For compound 4 the middle estimate is 170-fold (2.24 log units) above the measured one, outside the stated range (below it).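

In this assay, the aromatic carbon opposite the ring nitrogen proves sensitive to the group it carries: methylsulfanyl gives an at least 100-fold lower number from compound 3 to compound 4 (2.03 log units; beyond the scatter), and it likewise gives an at least 100-fold lower number from compound 2 to compound 4 (2.03 log units; beyond the scatter) and an at least 100-fold lower number from compound 1 to compound 4 (2.03 log units; beyond the scatter). The steps among compound 1, compound 2 and compound 3 cannot be read, so those compounds could not show that the group at this carbon matters at all. Compound 4 now gives that position a first measured value, and its methylsulfanyl is the only one of the four groups shown that carries no ring, while the three ring-bearing groups stay at the limit: the limit of > 5000 nM in this assay, at which 3 of the 4 values shown sit.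

On these data alone, whether the gain belongs to the sulfur or to the absence of a ring remains open. A methoxy group or an ethylsulfanyl chain at this carbon would separate the two.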